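This account rests on a few compounds, and the source may have more. Where it says the series, first, only, none or still open, it means among the compounds named here.

Measured in a functional assay on MDA-MB-435 cells (Homo sapiens) for cytotoxicity, read by sulforhodamine B assay, with a stated time of 48 h; on this read-out higher numbers stand for weaker inhibition and lower numbers for stronger inhibition:
compound 1 `COC1=CC(=O)C(C)=C(CC(C)=O)C1=O` gives 2.22 ug/mL
compound 2 `COC1=CC(=O)C(C)=C(C[C@H](C)O)C1=O` gives 3.6 ug/mL

Among the compounds with values here, compound 2 stands level with compound 1 on these two numbers, the only step among them, a 1.6-fold higher number from compound 1 to compound 2 (0.21 log units; within the scatter), lying within the scatter. Compound 3 `COC1=CC(=O)C(C)=C(C[C@H](C)OC=O)C1=O` differs from compound 2 in one place: formyl in place of hydrogen on an oxygen on a saturated carbon. Within the data shown here, the single measured step, a 1.6-fold higher number from compound 1 to compound 2 (0.21 log units; within the scatter), concerns the same chain but not this oxygen, and it was within the scatter; no measured step touches formyl in place of hydrogen on an oxygen. In this assay no step beyond the scatter is therefore expected, in either direction, which means a 1.0-fold lower number from compound 2 to compound 3 (0.01 log units; within the scatter). Compound 3 is estimated at 3.5 ug/mL, expected between 1.5 ug/mL and 8 ug/mL.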

Compound 3, half-maximal inhibitory concentration: 2.9 ug/mL
The estimate for compound 3 lay 1.2-fold (0.08 log units) above the measured number, within the range that was stated.
By their numbers in this assay, from the lowest: compounds 1, 3 and 2 (each within the scatter of the next).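

In this assay, formyl in place of hydrogen on the oxygen gives a 1.2-fold lower number from compound 2 to compound 3 (0.09 log units; within the scatter) and so leaves no readable change at this position. The 1-(formyloxy)ethyl chain in place of acetyl gives a 1.3-fold higher number from compound 1 to compound 3 (0.12 log units; within the scatter) and likewise does not separate compound 3 from compound 1. Nothing on hand offers a reason for these results.

Within the data shown here, no step so far lies beyond the scatter, so how far this chain can alter the number stays open. An amine or a carboxylic acid in place of the formyloxy could still show whether this oxygen matters.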